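Methyl for hydrogen on the carbon bound to amide nitrogen

This account rests on a few compounds, and the source may have more. Where it says the series, first, only, none or still open, it means among the compounds named here.

Compound 1 `COc1ccc(C(=C/C=C/C(=O)NCCCCc2cccnc2)c2ccc(OC)c(OC)c2)cc1OC` carries an unbranched 4-(pyridin-3-yl)butyl chain on the amide nitrogen; in a functional assay on the whole organism for inhibition, with Cavia porcellus as the target, with a stated time of 2 h (on this read-out higher numbers stand for an effect only at larger amounts of compound and lower numbers for an effect already at smaller amounts), compound 1 gives 27 mg/kg. Compound 2 `CC/C(=C\C=C\C(=O)N[C@H](C)CCCc1cccnc1)c1ccc(OC)cc1` already has the 1-methyl-4-(pyridin-3-yl)butyl chain on a different core, and in this assay compound 2 gives 35 mg/kg. Compound 3 `COc1ccc(/C(=C/C=C/C(=O)N[C@H](C)CCCc2cccnc2)C(C)C)cc1` is compound 2 with methyl in place of hydrogen on a saturated chain carbon bound to a double-bonded chain carbon and a saturated chain carbon, and in this assay compound 3 gives 30 mg/kg. That change made a 1.2-fold lower number from compound 2 to compound 3 (0.07 log units; within the scatter). The difference between the core of compound 1 and the core of compound 2 is not broken down here; the two values sit within the scatter of each other, as does the value of compound 1 against compound 3.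

Compound 4 `COc1ccc(C(=C/C=C/C(=O)N[C@H](C)CCCc2cccnc2)c2ccc(OC)c(OC)c2)cc1OC` is compound 1 with methyl in place of hydrogen on a saturated chain carbon bound to an amide-type nitrogen and a saturated chain carbon. Within the data shown here, this is the same kind of change as the one from compound 2 to compound 3, but not the same: there the methyl entered on a saturated chain carbon bound to a double-bonded chain carbon and a saturated chain carbon, here it enters on a saturated chain carbon bound to an amide-type nitrogen and a saturated chain carbon. Compounds 2 and 3, which both already carry the methyl at this amide-side place, and compound 1, which does not, all lie within the scatter of one another.

The step from compound 1 to compound 4 is therefore expected to be small, a 1.1-fold lower number from compound 1 to compound 4 (0.03 log units; within the scatter), because a 1.2-fold lower number from compound 2 to compound 3 (0.07 log units; within the scatter) lies within the scatter. Compound 2 gives 35 mg/kg, compound 3 gives 30 mg/kg and compound 1 gives 27 mg/kg, and these three values sit close to one another. Compound 4 is estimated at 25 mg/kg in this assay, expected between 12 mg/kg and 50 mg/kg.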

Compound 4, dose for 50% inhibition: 26 mg/kg
For compound 4 the middle estimate is 1.0-fold (0.02 log units) below the measured one; the range from low to high includes it.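

In this assay, methyl in place of hydrogen on a saturated chain carbon bound to an amide-type nitrogen and a saturated chain carbon gives a 1.0-fold lower number from compound 1 to compound 4 (0.02 log units; within the scatter), so the 1-methyl-4-(pyridin-3-yl)butyl chain and the unbranched 4-(pyridin-3-yl)butyl chain cannot be told apart on the core of compound 1. Set beside the earlier methyl step, the result reads as no measurable effect of the added methyl on either core, with no difference between the two steps: the same change on two cores in this assay, a 1.2-fold lower number (0.07 log units; within the scatter) from compound 2 to compound 3 and a 1.0-fold lower number (0.02 log units; within the scatter) from compound 1 to compound 4, 1.1-fold (0.05 log units) apart, within the scatter of two such steps. This does not show that a single effect carries from core to core, since the earlier methyl sits on a saturated chain carbon bound to a double-bonded chain carbon and not at the amide-side place, and two steps that both lie within the scatter would look alike on any core where the change does little.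

Open, as far as these compounds go, is whether an ethyl or a cyclopropyl in place of this methyl, or a longer chain in place of the 4-(pyridin-3-yl)butyl chain, would move the number beyond the scatter in this assay. Also open, from the compounds shown here alone, is the opposite configuration at the methyl-bearing carbon, as compounds 2, 3 and 4 all carry the same one.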